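The compounds below may be only part of what the source reports. "The series", "measured", "known", "first", "only" and "open" are said of these compounds alone.

Among the measured compounds shown here, compound 1 `c1ccc(-c2ccnc(Nc3cccc(OCCn4ccnc4)c3)n2)nc1` gives 400 nM in a functional assay for inhibition, with Homo sapiens as the target (on this read-out higher numbers stand for weaker inhibition and lower numbers for stronger inhibition), the higher of the two numbers measured so far. Compound 2 `c1cc(Nc2nccc(-c3ccco3)n2)cc(OCCn2ccnc2)c1` gives 200 nM, and the step of a 2.0-fold lower number from compound 1 to compound 2 (0.30 log units; within the scatter) involves a different part of the molecule. Compound 3 `CC(=O)Nc1cccc(Nc2nccc(-c3ccccn3)n2)c1` has not yet been measured; it differs from compound 1 by acetamido in place of 2-(1H-imidazol-1-yl)ethoxy on an aromatic carbon. No measured step touches this position, so nothing shown points to a change in this assay beyond the scatter, although the uncertainty is wide. Compound 3 is therefore expected to give about 500 nM, within a range of 100 nM to 3000 nM. The expected step of a 1.3-fold higher number from compound 1 to compound 3 (0.10 log units; within the scatter) is thus a modest one.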

Compound 3, half-maximal inhibitory concentration: 300 nM
Estimate against measurement, compound 3: 1.7-fold (0.22 log units) above; the measured number falls inside the stated range.
By their numbers in this assay, from the lowest: compounds 2, 3 and 1 (each within the scatter of the next).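

Replacing 2-(1H-imidazol-1-yl)ethoxy with the smaller acetamido, which has no ring, gives a 1.3-fold lower number from compound 1 to compound 3 (0.12 log units; within the scatter) in this assay. In this pair, then, the imidazole ring and its ethoxy link are not needed to keep a number of this size, and this position accepts two quite different groups. No available evidence explains this result. Still open, going by these compounds, is how a simple amine, a carboxylic acid or a longer chain would fare at this position. Also open, on these data alone, is whether acetamido gives a similar number when furan-2-yl replaces pyridin-2-yl.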